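Swapping bromophenyl for thiophene in a cyclic imide urea series

The compounds below may be only part of what the source reports. "The series", "measured", "known", "first", "only" and "open" are said of these compounds alone.

Compound 1, `O=C(NCc1ccccc1Br)N1C(=O)c2ccccc2S1(=O)=O`, gives > 166 h in a physicochemical assay for pharmacokinetics; a lower number here means that the compound disappears faster, a higher number that the compound lasts longer; that value is a limit of the assay, not a number.
Compound 2, `O=C(NCc1cccc(Br)c1)N1C(=O)c2ccccc2S1(=O)=O`, gives > 166 h in this assay; again a limit.
Compound 3, `O=C(NCc1ccccc1)N1C(=O)c2ccccc2S1(=O)=O`, gives > 166 h in this assay; again a limit.

Compound 1 therefore stands at the edge of what this assay can report, and so do both of its neighbours: the limit of > 166 h in this assay, at which 3 of the 3 values shown sit. The steps a step that the two limits leave unreadable from compound 1 to compound 2 and a step that the two limits leave unreadable from compound 1 to compound 3 cannot be sized for the same reason.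

Compound 4, `O=C(NCc1cccs1)N1C(=O)c2ccccc2S1(=O)=O`, differs from compound 1 by thiophen-2-yl in place of 2-bromophenyl on a saturated chain carbon bound to an amide-type nitrogen. Going by the values given here, no measured step is readable, so no direction can be drawn from them. Compound 4 is expected to reach the same limit, with an estimated 166 h between 80 h and 400 h. The expected step is a number no higher from compound 1 to compound 4 (the limit leaves the size open).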

Compound 4, half-life: > 166 h
Compound 4 ended at the assay's limit; the forecaster's own chance of this, stated with the estimate: 75%; the middle value lies on the limit itself.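

No step from compound 4 to compound 1, compound 2 or compound 3 can be read, because all four compounds share one assay limit: the limit of > 166 h in this assay, at which 4 of the 4 values shown sit.

Going by these compounds, how long each compound really lasts in this assay, and whether thiophen-2-yl, phenyl, 2-bromophenyl or 3-bromophenyl changes that, stays open.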